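Bromine to methoxy on the phenyl of compound 1

This account rests on a few compounds, and the source may have more. Where it says the series, first, only, none or still open, it means among the compounds named here.

Of the compounds shown here, three sharing one core have been measured. In a functional assay on A549 cells (Homo sapiens) for antiproliferative activity, read by MTT assay, with a stated time of 72 h (a higher number here means a weaker inhibitor, a lower number a stronger inhibitor), compound 1 `O=C1O/C(=C\Cn2cc(-c3ccc(Br)cc3)nn2)C(OCc2ccccc2)=C1OCc1ccccc1` gives only a limit, > 100000 nM, and not a number. Compound 2 `O=C1O[C@H]([C@@H](O)Cn2cc(-c3cccc(O)c3)nn2)C(OCc2ccccc2)=C1OCc1ccccc1` gives 59900 nM in this assay. Compound 3 `CCCCc1cn(C[C@H](O)[C@H]2OC(=O)C(OCc3ccccc3)=C2OCc2ccccc2)nn1` gives 28600 nM. Going by the values given here, the only single-point change measured so far, a 2.1-fold lower number from compound 2 to compound 3 (0.32 log units; beyond the scatter), exchanges the whole group hanging from the shared core, butyl in place of 3-hydroxyphenyl, and is modest in size.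

Compound 4 `COc1ccc(-c2cn(C/C=C3\OC(=O)C(OCc4ccccc4)=C3OCc3ccccc3)nn2)cc1` differs from compound 1 by methoxy in place of bromo on an aromatic carbon, para to a large group, or read one bond further out, 4-bromophenyl to 4-methoxyphenyl. Among the compounds with values here, no measured step swaps one small substituent on that phenyl ring for another, so the modest step from compound 2 to compound 3 bears on it only loosely. As far as these compounds go, compound 1 itself sits at the limit (the limit of > 100000 nM in this assay, at which 1 of the 3 values shown sits), so its true number is unknown. The step of a number no higher from compound 1 to compound 4 (the limit leaves the size open) is expected to be small, with no clear direction beyond the scatter. Compound 4 is therefore estimated at 100000 nM, with a range from 30000 nM to 300000 nM.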

Compound 4, half-maximal inhibitory concentration: > 100000 nM
Compound 4 gave a limit, no number; the forecaster's own chance of this, stated with the estimate: 60%; the middle value lies on the limit itself.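

Compound 1 and compound 4 each give only a limit in this assay, not a number, so the step between them cannot be read: the limit of > 100000 nM in this assay, at which 2 of the 4 values shown sit.

The compounds shown leave open whether methoxy in place of bromo changes activity at all, and where the true number of either compound lies.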